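Acyl-thiourea benzimidazoles: swapping the benzyloxy aryl group

This account rests on a few compounds, and the source may have more. Where it says the series, first, only, none or still open, it means among the compounds named here.

Measured so far:
Compound 1 `Cc1ccc(NC(=S)NC(=O)c2ccc(OCc3cccc(Cl)c3)cc2)cc1-c1nc2ccccc2[nH]1` — 35300 nM
Compound 2 `Cc1ccc(NC(=S)NC(=O)c2ccc(OCc3cccc(Cl)c3Cl)cc2)cc1-c1nc2ccccc2[nH]1` — 63700 nM

Both numbers come from a functional assay on HT-29 cells (Homo sapiens) for inhibition, read by MTT assay, with a stated time of 48 h; on this read-out lower numbers stand for stronger inhibition and higher numbers for weaker inhibition. Among the measured compounds shown here, compound 2 gives the highest of the two numbers, with compound 1 as its only neighbour, and the one step that connects them, a 1.8-fold higher number from compound 1 to compound 2 (0.26 log units; within the scatter), lies within the scatter, so the two compounds cannot be ranked against each other.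

Compound 3 `Cc1ccc(NC(=S)NC(=O)c2ccc(OCc3cccc(F)c3)cc2)cc1-c1nc2ccccc2[nH]1` has not yet been measured in this assay. It differs from compound 2 by 3-fluorophenyl in place of 2,3-dichlorophenyl on a saturated chain carbon bound to an oxygen on an aromatic ring. For the measured compounds named here, the only measured step that touches this region is a 1.8-fold higher number from compound 1 to compound 2 (0.26 log units; within the scatter), which was small; undoing the second chlorine is therefore expected to move the number little, and the data say nothing about fluorine against chlorine. The step from compound 2 to compound 3 is expected to be a 1.5-fold lower number from compound 2 to compound 3 (0.18 log units; within the scatter), not beyond the scatter. Compound 3 is thus estimated at 42000 nM, within a range of 15000 nM to 120000 nM.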

Compound 3, half-maximal inhibitory concentration: 55300 nM
For compound 3 the middle estimate is 1.3-fold (0.12 log units) below the measured one, within the range that was stated.
By their numbers in this assay, from the lowest: compounds 1, 3 and 2 (each within the scatter of the next).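

In this assay the swap of 2,3-dichlorophenyl for 3-fluorophenyl on a saturated chain carbon bound to an oxygen on an aromatic ring gives a 1.2-fold lower number from compound 2 to compound 3 (0.06 log units; within the scatter) and fluoro in place of chloro on an aromatic carbon gives a 1.6-fold higher number from compound 1 to compound 3 (0.19 log units; within the scatter) with both steps lying within the scatter. The earlier pair spoke only to a second chlorine, whereas these steps add fluorine against chlorine at this position, and compound 1, compound 2 and compound 3 cannot be ranked against one another. No evidence on the cause of this result is available.

The compounds shown all carry halogen on the benzyl group. They leave open whether a methoxy group, a nitrile or an amine on that benzyl group, or a plain hexyl chain in its place, would give a step beyond the scatter.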